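A fluorine on the anilino ring of a curcumin-like scaffold

A few compounds are considered here, and "the series" means these few. Any claim that something is new, unique, unknown or untested is made for them only; others in the source may bear on it.

Of the compounds shown here, two sharing the same core have been measured in a physicochemical assay, read by spectrophotometry; on this read-out higher numbers stand for weaker inhibition and lower numbers for stronger inhibition. Compound 1, `CN(C)c1ccc(/C=C/C(=O)/C=C(O)/C=C/c2ccc(N(C)C)cc2)cc1`, is the parent; in this assay compound 1 gives 78.5 ug/mL. Compound 2, `CN(C)c1ccc(/C=C/C(=O)/C(CNc2ccccc2)=C(O)/C=C/c2ccc(N(C)C)cc2)cc1`, carries an anilinomethyl group on the central chain; in this assay compound 2 gives 79.1 ug/mL. On the numbers shown, compound 2 holds the higher of the two values, but its distance from compound 1 lies within the usual scatter, so the two cannot be told apart.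

The next compound, compound 3, `CN(C)c1ccc(/C=C/C(=O)/C(CNc2ccc(F)cc2)=C(O)/C=C/c2ccc(N(C)C)cc2)cc1`, is not yet measured. It differs from compound 2 in a single place: fluoro in place of hydrogen on an aromatic carbon. The change is small, one fluorine on an aromatic carbon of the anilino ring, para to a large group.

Within the data shown here, no step between measured compounds is available to guide the size of this change, so the expectation rests on the two values alone. Compound 3 is expected to stay close to compound 2, with a step of a 1.1-fold lower number from compound 2 to compound 3 (0.02 log units; within the scatter) that is not expected to exceed the scatter. Compound 3 is therefore estimated at 75 ug/mL, within a range of 40 ug/mL to 150 ug/mL.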

Compound 3, half-maximal inhibitory concentration: 48.2 ug/mL
Estimate against measurement, compound 3: 1.6-fold (0.19 log units) above; measured number inside the range.
By their numbers in this assay, from the lowest: compounds 3, 1 and 2 (each within the scatter of the next).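

In this assay the exchange of hydrogen for fluoro on the aromatic carbon of the anilino ring gives a 1.6-fold lower number from compound 2 to compound 3 (0.22 log units; within the scatter) and so stays within the scatter, which means that compound 3 cannot be told apart from compound 2 on this read-out. Among these compounds, the earlier compounds showed only that the core of compound 1 and its anilinomethyl-bearing counterpart give values that cannot be separated; this pair adds that the ring of the anilinomethyl group can also carry a fluoro at this place, para to a large group, without a step that clears the scatter. No measurement is available that could account for the size of this step.

The compounds shown leave open whether this place on the ring can give a step beyond the scatter at all, since a single fluoro is a small probe, and a chloro, a methoxy, a nitrile or a carboxylic acid there would test it more widely. They also leave open whether a longer chain in place of the methyl link, or an alkyl amine in place of the anilino group, would move the number any further.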